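This account rests on a few compounds, and the source may have more. Where it says the series, first, only, none or still open, it means among the compounds named here.

Three amides built on the same trans-cinnamoyl backbone have been tested in a functional assay on SH-SY5Y cells (Homo sapiens) for cytotoxicity, read by MTT assay, with stated times of 24 h and 4 h; on this read-out higher numbers stand for an effect only at larger amounts of compound and lower numbers for an effect already at smaller amounts. Compound 1 `COc1cccc(/C=C/C(=O)NCc2ccc(O)c(OC)c2)c1` gives 5240 nM in this assay. Compound 2 `COc1cccc(/C=C/C(=O)NCc2ccc(OCc3nc(C)c(C)nc3C)c(OC)c2)c1` gives 4320 nM, and the step of a 1.2-fold lower number from compound 1 to compound 2 (0.08 log units; within the scatter) is small. The two cores differ as follows, read from compound 2 to compound 1: hydrogen in place of (3,5,6-trimethylpyrazin-2-yl)methyl on an oxygen on an aromatic ring. Compound 3 `COc1cc(CNC(=O)/C=C/c2cccc(OC)c2OC)ccc1OCc1nc(C)c(C)nc1C` gives 7150 nM in this assay, and the step of a 1.7-fold higher number from compound 2 to compound 3 (0.22 log units; within the scatter) is likewise small. The change that turns compound 2 into compound 3 is methoxy in place of hydrogen on an aromatic carbon.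

Compound 4 `COc1cc(/C=C/C(=O)NCc2ccc(O)c(OC)c2)cc(OC)c1` has not yet been measured. It arises from compound 1 by methoxy in place of hydrogen on an aromatic carbon. Among the compounds with values here, this is the same kind of change as the one from compound 2 to compound 3, but not the same: in compound 3 the new methoxy sits ortho to a large group and ortho to a methoxy group, whereas in compound 4 it sits meta to a large group and meta to a methoxy group. Because the measured step of a 1.7-fold higher number from compound 2 to compound 3 (0.22 log units; within the scatter) stayed within the usual scatter, only a small step is expected here too. The step from compound 1 to compound 4 is therefore estimated at a 1.3-fold higher number from compound 1 to compound 4 (0.13 log units; within the scatter) in this assay. For compound 4 the expected value in this assay is 7000 nM, most likely lying between 3500 nM and 14000 nM.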

Compound 4, half-maximal effective concentration: 4860 nM
Estimate against measurement, compound 4: 1.4-fold (0.16 log units) above; low and high end bracket the measured number.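

In this assay the added methoxy gives a 1.1-fold lower number from compound 1 to compound 4 (0.03 log units; within the scatter), so on the core of compound 1 this change leaves the number where it was, within the scatter of the measurement. Set beside the earlier step, the change carries over from one core to the other without a difference that can be told from scatter: the same change on two cores in this assay, a 1.7-fold higher number (0.22 log units; within the scatter) from compound 2 to compound 3 and a 1.1-fold lower number (0.03 log units; within the scatter) from compound 1 to compound 4, 1.8-fold (0.25 log units) apart, within the scatter of two such steps This shows that in these two pairs the methoxy changes the read-out by no more than repeat measurements would, but it rests on only two steps in one assay, the methoxy does not stand at the same place in the two pairs, and neither step has a direction that can be trusted, so it gives no general rule for the series and does not show that the place of the methoxy is unimportant.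

The compounds shown leave open whether an amine, a carboxylic acid or a longer chain such as propoxy, put on the ring in place of the methoxy, would also stay within the scatter. They also leave open what the same methoxy would do on a core with a different amide part, where a step large enough to read might or might not appear.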